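Swapping a Halogenated Phenyl Ring on a Sulfonamide

The source may report more compounds than this note shows. Statements on the series, on what has been measured and on what is new or still open speak of the compounds shown alone.

Compound 2, `CC1CCN(C2CCN(S(=O)(=O)c3ccc(-c4ccccc4F)cc3)CC2)CC1`, gives 5 nM in a functional assay on DLD-1 cells (Homo sapiens) for antiproliferative activity, read by CellTiter-Glo, with a stated time of 72 h; a higher number here means a weaker inhibitor, a lower number a stronger inhibitor. Compound 1, `CC1CCN(C2CCN(S(=O)(=O)c3ccc(Br)cc3OC(F)(F)F)CC2)CC1`, gives 5 nM in this assay; the two values are level at the digits shown, within the usual scatter. Compound 3, `CC1CCN(C2CCN(S(=O)(=O)c3ccc(-c4ccc(Cl)cc4)cc3)CC2)CC1`, has not yet been measured. It differs from compound 2 in one place: 4-chlorophenyl in place of 2-fluorophenyl on an aromatic carbon. Going by the values given here, no step between measured compounds of this kind is available, so the size of the change is unknown. The expected step, a 1.2-fold higher number from compound 2 to compound 3 (0.08 log units; within the scatter), stays within the scatter. The estimate for compound 3 in this assay is 6 nM, within a range from 2 nM to 20 nM.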

Compound 3, half-maximal inhibitory concentration: 105 nM
The estimate for compound 3 lay 18-fold (1.24 log units) below the measured number; measured number outside the range, above it.
By their numbers in this assay, from the lowest: compounds 1 and 2 (each within the scatter of the next); then compound 3.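

This position is not indifferent to which halogenated phenyl group it carries: in this assay, 4-chlorophenyl in place of 2-fluorophenyl gives a 21-fold higher number from compound 2 to compound 3 (1.32 log units; beyond the scatter), a large step beyond the scatter. The two groups have the same heavy-atom count and the same ring, and neither has hydrogen-bond donors or acceptors, so these counts do not separate them. No measurement shown here accounts for the step. The compounds shown do not separate the change of halogen from the change in its place on the ring, and 4-fluorophenyl or 2-chlorophenyl would bear on that. As far as these compounds go, how an amine or a carboxylic acid on this ring would fare also stays open.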